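The source may hold more compounds than are shown below. What is called first, only, known or untested is meant among the compounds shown, and "the series" means these compounds.

The measured compounds:
compound 1, `Cc1ccc(/C=C/C(=O)Nc2ccc3ncnc(Nc4cccc(Br)c4)c3c2)cc1`, 1.39 ug/mL;
compound 2, `COc1cccc(/C=C/C(=O)Nc2ccc3ncnc(Nc4cccc(Cl)c4)c3c2)c1`, 1.05 ug/mL.

In a functional assay on B16-F10 cells (Mus musculus) for inhibition, read by MTT assay, with a stated time of 48 h (a lower number here means a stronger inhibitor, a higher number a weaker inhibitor), compound 2 gives 1.05 ug/mL. Compound 1 gives 1.39 ug/mL in this assay, and the two numbers lie within the scatter of each other, so neither compound can be set apart from the other. Among the measured compounds shown here, the two differ in two places at once, so no single step between them can be read.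

Compound 3, `Cc1ccc(/C=C/C(=O)Nc2ccc3ncnc(Nc4cccc(Cl)c4)c3c2)cc1`, has not yet been measured. It differs from compound 2 by 4-methylphenyl in place of 3-methoxyphenyl on a double-bonded chain carbon bound to a double-bonded chain carbon. Since compound 1 already carries the 4-methylphenyl group and gives 1.39 ug/mL, the change is expected to bring no step beyond the scatter, in either direction. Compound 3 is therefore estimated at 1.3 ug/mL, with a range from 0.6 ug/mL to 2.8 ug/mL, which means an expected step of a 1.2-fold higher number from compound 2 to compound 3 (0.09 log units; within the scatter).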

Compound 3, half-maximal inhibitory concentration: 2.02 ug/mL
Compound 3: the middle estimate sits 1.6-fold (0.19 log units) below what was measured, within the range that was stated.
By their numbers in this assay, from the lowest: compounds 2, 1 and 3 (each within the scatter of the next).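

In this assay, 4-methylphenyl in place of 3-methoxyphenyl on a double-bonded chain carbon bound to a double-bonded chain carbon gives a 1.9-fold higher number from compound 2 to compound 3 (0.28 log units; within the scatter), so this change, now readable on its own, cannot be set apart from the scatter. Chloro in place of bromo on an aromatic carbon, also readable on its own for the first time, gives a 1.5-fold higher number from compound 1 to compound 3 (0.16 log units; within the scatter), so neither single change separates the compounds in this assay. No measurement is available that would explain these results.

The compounds shown leave open whether 4-methoxyphenyl or 3-methylphenyl at this place would separate the methoxy-to-methyl exchange from the shift in the group's position on the ring. They also leave open whether an aminophenyl or carboxyphenyl group there would give a step beyond the scatter.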